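A few compounds are considered here, and "the series" means these few. Any claim that something is new, unique, unknown or untested is made for them only; others in the source may bear on it.

Measured so far in an assay on isolated protein for inhibition of leukotriene B4 receptor 1 (Homo sapiens), tested at 10 uM; a lower number here means less inhibition, a higher number more inhibition at the concentration tested (going by the name of the read-out):

compound 1, `CCc1cc(C(C)=O)c(O)cc1OCCCCCCCC(C)(C)C#N`: 66%
compound 2, `C=CCc1cc(C(C)=O)c(O)cc1OCc1ccccc1C#N`: 47%
compound 3, `C=CCc1cc(C(C)=O)c(O)cc1OCc1cccc(C#N)c1`: 71%

Compound 3 gives the highest of the three numbers. The nearest is compound 1, whose number is lower by an amount within the usual scatter, so no order between compound 3 and compound 1 can be read from these two values. Compound 2 sits furthest, lower by an amount beyond the scatter.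

Compound 4, `CCc1cc(C(C)=O)c(O)cc1OCc1cccc(C#N)c1`, has not been measured. Against compound 3 the counted difference is methyl in place of vinyl on a saturated chain carbon bound to an aromatic carbon. Cut one bond further out, the same difference reads allyl to ethyl.

Going by the values given here, no pair of measured compounds differing in one place is available, so no step of this kind has been seen. Among the compounds with values here, the only hint is that compound 1 and compound 3 give numbers within the scatter of each other. On that basis the step from compound 3 to compound 4 in this assay is expected to stay within the scatter, with no clear direction. The estimate for compound 4 is 66%, expected to fall between 50% and 80%. The expected step from this estimate is a number 5 percentage points lower from compound 3 to compound 4 (within the scatter).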

Compound 4, a percentage reported as inhibition, at one concentration (the size of the read-out at that concentration, not a potency): 58%
For compound 4 the middle estimate is 8 percentage points above the measured one; the range from low to high includes it.
By their numbers in this assay, from the lowest: compound 2; then compounds 4, 1 and 3 (each within the scatter of the next, the first and the last beyond it).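

In this assay, going by these compounds alone, the change of allyl to ethyl gives the first step that can be read: a number 13 percentage points lower from compound 3 to compound 4 (beyond the scatter), a modest step beyond the usual scatter. It shows that the group on the saturated chain carbon bound to an aromatic carbon affects the read-out with the rest of the structure unchanged, although compound 4 still gives 58% in this assay and inhibition at the concentration tested therefore does not depend on the presence of the vinyl. No measurement at hand bears on what lies behind this step.

A propyl group at this place would help to tell whether the step follows the loss of the double bond or the shorter chain, and a longer chain or a cyclopropyl group would show how much room for change this place allows. Also open, going by these compounds, is whether methyl in place of vinyl has a step of similar size when the nitrile-bearing group elsewhere in the structure is replaced by the side chain of compound 1 or that of compound 2.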